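Removing the nitrile from a bis-indolyl pyridine

A few compounds are considered here, and "the series" means these few. Any claim that something is new, unique, unknown or untested is made for them only; others in the source may bear on it.

The series comprises three measured compounds and one yet to be tested. Compound 1 `Cc1ccc(S(=O)(=O)n2cc(-c3cc(C(F)(F)F)c(C#N)c(-c4cn(S(=O)(=O)c5ccc(C)cc5)c5ccc(Br)cc45)n3)c3cc(Br)ccc32)cc1` gives 9.8% in a functional assay on A549 cells (Homo sapiens) for inhibition, tested at 0.1 uM; a lower number here means a weaker effect, a higher number a stronger effect of the compound at the concentration tested. Compound 2 `Cc1ccc(S(=O)(=O)n2cc(-c3cc(C(F)(F)F)ccn3)c3cc(Br)ccc32)cc1` gives 38.9% in this assay. Compound 3 `COc1ccc2c(c1)c(-c1cc(C(F)(F)F)c(C#N)c(-c3cn(S(=O)(=O)c4ccc(C)cc4)c4ccc(OC)cc34)n1)cn2S(=O)(=O)c1ccc(C)cc1` gives 25% in this assay, the second highest of the three numbers: compound 2 sits beyond the scatter above it, and compound 1 beyond the scatter below it.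

Compound 4 `COc1ccc2c(c1)c(-c1cc(C(F)(F)F)cc(-c3cn(S(=O)(=O)c4ccc(C)cc4)c4ccc(OC)cc34)n1)cn2S(=O)(=O)c1ccc(C)cc1` is the counterpart of compound 3 without the nitrile. The change is hydrogen in place of cyano on an aromatic carbon. Going by the values given here, no pair among the measured compounds differs by this change alone, so the size of the step cannot be read from a measured analogue. Compound 2, which also carries no nitrile on its ring, shows the highest value of the three, but it differs from compound 3 in more than one place. On this basis compound 4 is expected to land somewhat above compound 3, with a step of a number 6 percentage points higher from compound 3 to compound 4 (within the scatter) that may not exceed the scatter. The estimate for compound 4 in this assay is 31%, within a range from 15% to 47%.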

Compound 4, a percentage reported as inhibition, at one concentration (the size of the read-out at that concentration, not a potency): 16.7%
Estimate against measurement, compound 4: 14.3 percentage points above, within the range that was stated.
By their numbers in this assay, from the lowest: compounds 1, 4 and 3 (each within the scatter of the next, the first and the last beyond it); then compound 2.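

In this assay, going by these compounds alone, the exchange of cyano for hydrogen gives the first direct reading at this position, a number 8.3 percentage points lower from compound 3 to compound 4 (within the scatter), so compound 3 and compound 4 cannot be told apart at the single concentration tested. Within the data shown here, on this core, the aromatic carbon ortho to a trifluoromethyl group and two atoms from the ring nitrogen can thus carry either cyano or hydrogen with no difference that this read-out resolves, something no earlier pair could show. Nothing available explains this result or bears on it.

On these data alone, it remains open whether an amine, a carboxylic acid or a longer chain on this same carbon would separate from compound 3 beyond the scatter. As far as these compounds go, it is also open whether the same exchange on compound 1, which carries bromine on both indole units, would give a comparable step.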